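A few compounds are considered here, and "the series" means these few. Any claim that something is new, unique, unknown or untested is made for them only; others in the source may bear on it.

Measured compounds:
Compound 1, `COc1ccc(F)c([C@H]2CC[C@H](COc3cccc([C@@H](CC(=O)O)C4CC4)c3)CC2)c1`, giving 4.1 nM in a functional assay on HEK293 cells for agonist activity at Free fatty acid receptor 1 (Rattus norvegicus), read by FLIPR and calcium flux; a higher number here means that more compound is needed for the effect, a lower number that less compound is needed.
Compound 2, `COc1ccc(F)c([C@H]2CC[C@H](COc3cccc([C@H](C4CC4)[C@H](F)C(=O)O)c3)CC2)c1`, giving 163 nM in this assay.

Compound 2 has the highest number of the two in this assay; the nearest is compound 1, separated by a 40-fold higher number from compound 1 to compound 2 (1.60 log units; beyond the scatter). That single measured step is the only one on hand, and it shows that a change at the carbon bound to the carbonyl, next in line after the cyclopropyl-bearing carbon, has a large effect.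

Compound 3, `COc1ccc(F)c([C@H]2CC[C@H](COc3cccc([C@H](C4CC4)C(C)(C)C(=O)O)c3)CC2)c1`, is not yet measured. It differs from compound 2 by 1-carboxy-1-methylethyl in place of carboxy(fluoro)methyl on a saturated chain carbon bound to an aromatic carbon and a saturated ring carbon. Among the measured compounds shown here, both compounds 2 and 3 carry a substituent at the same carbon that compound 1 leaves bare; the step of a 40-fold higher number from compound 1 to compound 2 (1.60 log units; beyond the scatter) bears on this only indirectly, since what enters in compound 3 is two methyl groups rather than fluorine, and no measured pair isolates that exchange. The reading for compound 3 is therefore expected to stay in the region of compound 2, with the step of a 1.4-fold lower number from compound 2 to compound 3 (0.13 log units; within the scatter) lying within the scatter.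

Compound 3 is thus estimated at 120 nM, in a range from 25 nM to 600 nM.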

Compound 3, half-maximal effective concentration: 0.31 nM
The estimate for compound 3 lay 390-fold (2.59 log units) above the measured number; the whole stated range lies above it.
By their numbers in this assay, from the lowest: compound 3; then compound 1; then compound 2.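

In this assay, the carbon bound to the carbonyl can move the number in either direction: 1-carboxy-1-methylethyl in place of carboxy(fluoro)methyl gives a 530-fold lower number from compound 2 to compound 3 (2.72 log units; beyond the scatter), and the same group in place of carboxymethyl gives a 13-fold lower number from compound 1 to compound 3 (1.12 log units; beyond the scatter). The only substitution at this carbon seen before, fluoro in place of hydrogen, had gone the other way, with a 40-fold higher number from compound 1 to compound 2 (1.60 log units; beyond the scatter), so among these three compounds the outcome depends on what enters rather than on substitution there as such. No measurement at hand explains why the two substitutions part so widely.

The compounds shown leave open whether both methyl groups are needed, as none carries a single methyl at this carbon, and whether ethyl groups or a cyclopropane ring built on that carbon would keep so low a number. They also leave open how two fluorines at this carbon, or the opposite configuration at the fluorine-bearing carbon of compound 2, would read, and whether a tetrazole could stand in for the carboxylic acid.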